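A Triazole Aryl Swap on a Scaffold Without Measured Potency

A few compounds are considered here, and "the series" means these few. Any claim that something is new, unique, unknown or untested is made for them only; others in the source may bear on it.

Compound 1, `COc1ccccc1-n1nncc1CN1C(=O)C2(C(C#N)=C(N)Oc3c2c2nc4ccccc4nc2c2ccccc32)c2ccccc21`: in a functional assay on A549 cells (Homo sapiens) for antiproliferative activity, read by MTT assay, with a stated time of 48 h (on this read-out higher numbers stand for weaker inhibition and lower numbers for stronger inhibition), compound 1 gives > 50000 nM, which is a limit of the assay and not a number.
Compound 2, `CCOc1ccc(-n2nncc2CN2C(=O)C3(C(C#N)=C(N)Oc4c(N)cc5nc6ccccc6nc5c43)c3ccccc32)cc1`: in this assay compound 2 gives > 50000 nM, again a limit of the assay and not a number.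

For the measured compounds named here, compound 2 therefore stands at the limit of > 50000 nM in this assay, at which 2 of the 2 values shown sit, so no number places it relative to compound 1; the two values show only that neither compound reached a measurable half-maximal inhibitory concentration.

Compound 3, `Cc1ccc(-n2nncc2CN2C(=O)C3(C(C#N)=C(N)Oc4c(N)cc5nc6ccccc6nc5c43)c3ccccc32)cc1Cl`, has not yet been measured. It differs from compound 2 in one place: 3-chloro-4-methylphenyl in place of 4-ethoxyphenyl on an aromatic nitrogen. The shared core, including the nitrile, the amine and the fused ring system, is unchanged.

Going by the values given here, no step between measured compounds exists here, so no measured trend guides the expectation. With both measured compounds sitting at the limit, the change at the aromatic nitrogen is expected to produce no step beyond the scatter, and the estimated step that the limit leaves unreadable from compound 2 to compound 3 reflects that. Compound 3 is expected to give 60000 nM in this assay, most likely again as a limit, within a range of 15000 nM to 200000 nM.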

Compound 3, half-maximal inhibitory concentration: 11800 nM
Compound 3: the middle estimate sits 5.1-fold (0.71 log units) above what was measured, outside the stated range (below it).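

In this assay, putting 3-chloro-4-methylphenyl in place of 4-ethoxyphenyl on the aromatic nitrogen brings an at least 4.2-fold lower number from compound 2 to compound 3 (0.62 log units; beyond the scatter) and gives this small set its first value that is a number and not a limit of the assay. The two earlier results could not show that the group at this position of the five-membered aromatic ring with 3 nitrogen can move the read-out at all, while the shared core stays the same. As far as these compounds go, the step can only be stated as a minimum, and its full size stays unknown, because the starting point is a limit and not a number: the limit of > 50000 nM in this assay, at which 2 of the 3 values shown sit.

The change replaces the ethoxy group with both a chlorine and a methyl group, so the compounds shown do not tell which of the two accounts for the step, or whether both are needed. Also open, from the compounds shown here alone, is what the same ring would give if it carried an amine, a carboxylic acid or a longer alkyl chain in place of these groups.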